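A few compounds are considered here, and "the series" means these few. Any claim that something is new, unique, unknown or untested is made for them only; others in the source may bear on it.

Compound 1 `COC(=O)C1=C(C)N=C(C)/C(=C(\O)OC)C1c1cccc(OC(C)=O)c1`: 6030 nM
Compound 2 `C=Cc1ccccc1C1C(C(=O)OC)=C(C)N=C(C)/C1=C(\O)OC`: 4.47 nM
Compound 3 `COC(=O)C1=C(C)N=C(C)/C(=C(\O)OC)C1c1ccccc1C`: 6.03 nM

In a functional assay (muscle tissue) with Cavia porcellus as the target (a higher number here means that more compound is needed for the effect, a lower number that less compound is needed), compound 3 gives the second highest of the three numbers. Its nearest neighbour is compound 2, and the step of a 1.3-fold higher number from compound 2 to compound 3 (0.13 log units; within the scatter) lies within the scatter; compound 1 lies a long way off with a far higher number. Compound 4 `COC(=O)C1=C(C)N=C(C)/C(=C(\O)OC)C1c1cccc(Br)c1` has not been measured. Compared with compound 3 it shows (3-bromophenyl in place of 2-methylphenyl on a saturated ring carbon). Among the compounds with values here, no measured step covers this change: the only step known, a 1.3-fold higher number from compound 2 to compound 3 (0.13 log units; within the scatter), swaps one group for another at the same place and is flat. Compound 1, which also carries a substituent on the phenyl ring, gives 6030 nM, a much weaker result. The estimate for compound 4 in this assay is therefore a moderate loss, a 5.0-fold higher number from compound 3 to compound 4 (0.70 log units; beyond the scatter), giving 30 nM with a range from 4 nM to 250 nM.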

Compound 4, half-maximal effective concentration: 1.29 nM
Compound 4: the middle estimate sits 23-fold (1.37 log units) above what was measured, outside the stated range (below it).
By their numbers in this assay, from the lowest: compound 4; then compounds 2 and 3 (each within the scatter of the next); then compound 1.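

In this assay, the 3-bromophenyl group of compound 4 gives a lower number than either the 2-methylphenyl or the 2-vinylphenyl group, with a 4.7-fold lower number from compound 3 to compound 4 (0.67 log units; beyond the scatter) and a 3.5-fold lower number from compound 2 to compound 4 (0.54 log units; beyond the scatter). The group on the aromatic carbon also matters greatly, since bromo in place of acetoxy gives a 4700-fold lower number from compound 1 to compound 4 (3.67 log units; beyond the scatter). Nothing at hand explains these differences. The compounds shown leave open whether the gain follows the bromo group itself or its place on the phenyl ring. They also leave open how a 3-chlorophenyl, 3-nitrophenyl or 2-bromophenyl group would compare.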